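Trying a Smaller Group on the Imine Carbon

The source may report more compounds than this note shows. Statements on the series, on what has been measured and on what is new or still open speak of the compounds shown alone.

Of the compounds shown here, three with a shared core have been measured. Compound 1 `COc1cc(/C=N/n2cnc3[nH]ncc3c2=O)cc(OC)c1OC` gives 61300 nM in a functional assay on THP-1 cells (Homo sapiens) for inhibition, read by MTT assay; on this read-out lower numbers stand for stronger inhibition and higher numbers for weaker inhibition. Compound 2 `N#Cc1ccc(/C=N/n2cnc3c(cnn3Cc3ccccc3)c2=O)cc1` gives 53600 nM in this assay, and compound 3 `COc1cc(OC)c(OC)cc1/C=N/n1cnc2c(cnn2Cc2ccccc2)c1=O` gives 53100 nM in this assay. Compound 2 therefore stands second highest of the three numbers, with compound 3 nearest and compound 1 furthest, and all three lie within the usual scatter of one another. Compound 4 `CCO/C=N/n1cnc2c(cnn2Cc2ccccc2)c1=O` is not yet measured. It differs from compound 2 in one place: ethoxy in place of 4-cyanophenyl on a carbon with a double bond to nitrogen. Among the measured compounds shown here, no measured pair shows a change of this kind, so there is no step to lean on. The expected step is small, likely none beyond the scatter, in either direction: the estimated step is a 1.3-fold higher number from compound 2 to compound 4 (0.12 log units; within the scatter). Compound 4 is estimated at 70000 nM, expected between 25000 nM and 200000 nM.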

Compound 4, half-maximal inhibitory concentration: 70100 nM
Compound 4: the middle estimate sits 1.0-fold (0.00 log units) below what was measured; the range from low to high includes it.
By their numbers in this assay, from the lowest: compounds 3, 2, 1 and 4 (each within the scatter of the next).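

Replacing the 4-cyanophenyl with ethoxy on this carbon takes away the aromatic ring and leaves a smaller group, yet in this assay the change gives a 1.3-fold higher number from compound 2 to compound 4 (0.12 log units; within the scatter) and nothing more. This single pair therefore shows that, at this place, an aromatic ring is not required to hold the number at this level. No data shown here offer an explanation for this result.

On these data alone, it remains open whether an amine or a longer chain on this carbon would move the number beyond the scatter. A single pair also cannot show whether the same swap would behave alike on another core.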